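The source may report more compounds than this note shows. Statements on the series, on what has been measured and on what is new or still open speak of the compounds shown alone.

Measured compounds in a toxicity assay on Vero cells (Chlorocebus sabaeus) for cytotoxicity, read by colorimetric assay and MTT assay, with a stated time of 72 h; on this read-out higher numbers stand for lower toxicity in this test and lower numbers for higher toxicity in this test:

Compound 1, `Nc1cccc(F)c1C(=O)NNc1ccccc1Cl`: compound 1 gives 792000 nM.
Compound 2, `Nc1cccc(F)c1C(=O)NNc1ccc(Cl)cc1`: compound 2 gives 373000 nM.
Compound 3, `Nc1cccc(F)c1C(=O)NNc1cc(Cl)ccc1Cl`: for compound 3 the result is only a limit of the test, > 1800000 nM.

Compound 1 and compound 2 hold the same atoms joined differently; the difference between the two cores is not broken down here. Their numbers put compound 2 lowest of the two. From compound 1 to compound 3 the change is chloro in place of hydrogen on an aromatic carbon, giving an at least 2.2-fold higher number from compound 1 to compound 3 (0.35 log units; beyond the scatter), a step that ends at the limit (the limit of > 1800000 nM in this assay, at which 1 of the 3 values shown sits).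

Compound 4, `Nc1cccc(F)c1C(=O)NNc1ccc(Cl)c(Cl)c1`, is not yet measured. It differs from compound 2 by chloro in place of hydrogen on an aromatic carbon, the same kind of change as from compound 1 to compound 3, though the place differs: here the entering chloro sits ortho to a chloro group, there it sat para to a chloro group. By the earlier step, compound 4 is expected to show a 2.1-fold higher number from compound 2 to compound 4 (0.33 log units; beyond the scatter) in this assay. For compound 4 the estimate is 800000 nM, between 300000 nM and 1800000 nM.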

Compound 4, half-maximal cytotoxic concentration: > 1800000 nM
Compound 4 gave a limit, no number; the forecaster's own chance of this, stated with the estimate: 30%; at least 2.2-fold (0.35 log units) between middle value and limit.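

In this assay, chloro in place of hydrogen on the aromatic ring gives an at least 4.8-fold higher number from compound 2 to compound 4 (0.68 log units; beyond the scatter), so the number rises on this core as it did on the core of compound 1. This shows that the direction of the change carried over between these two cores, even with the chloro entering at a different place, but the size of the change did not carry over in any readable way: the same change on two cores in this assay, an at least 2.2-fold higher number (0.35 log units; beyond the scatter) from compound 1 to compound 3 and an at least 4.8-fold higher number (0.68 log units; beyond the scatter) from compound 2 to compound 4; the limit leaves it open whether they differ Compound 3 and compound 4 both stop at a limit of the test, not at a number: the limit of > 1800000 nM in this assay, at which 2 of the 4 values shown sit.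

The compounds shown leave open whether a methyl group or a nitrile in place of that chloro would move the number the same way. They also leave open whether the change would hold on a core without the fluoro group.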